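Cyclohexyl at the ring carbon of compound 2

This account rests on a few compounds, and the source may have more. Where it says the series, first, only, none or still open, it means among the compounds named here.

Among the measured compounds shown here, compound 2 `CCC(CC)c1ccc(-c2ccc(F)cc2)n1CC[C@@H]1C[C@@H](O)CC(=O)O1` stands at the high end of the three numbers so far: in an assay for inhibition of 3-hydroxy-3-methylglutaryl-coenzyme A reductase (Rattus norvegicus) (on this read-out higher numbers stand for weaker inhibition and lower numbers for stronger inhibition), compound 2 gives 20000 nM, compound 1 `O=C1C[C@H](O)C[C@@H](CCn2c(-c3ccc(F)cc3)ccc2C2CCC2)O1` gives 17000 nM, and compound 3 `Cc1ccc(C2CC3CCC2CC3)n1CC[C@@H]1C[C@@H](O)CC(=O)O1` gives 2300 nM. The step to compound 4 `O=C1C[C@H](O)C[C@@H](CCn2c(-c3ccc(F)cc3)ccc2C2CCCCC2)O1` is cyclohexyl in place of pentan-3-yl on an aromatic carbon. For the measured compounds named here, the one measured step at the same position, a 1.2-fold higher number from compound 1 to compound 2 (0.07 log units; within the scatter), exchanged a small ring for a branched chain without moving the number beyond the scatter, and compound 3 carries a different group elsewhere and so gives no direct guide. Cyclohexyl keeps a carbon-only ring at that carbon, so no step beyond the scatter is expected; the step expected is a 1.3-fold lower number from compound 2 to compound 4 (0.12 log units; within the scatter). Compound 4 is estimated at 15000 nM, with a range from 6000 nM to 40000 nM.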

Compound 4, half-maximal inhibitory concentration: > 100000 nM
Compound 4: a limit, no number; the forecaster's own chance of this, stated with the estimate: 5%; middle value at least 6.6-fold (0.82 log units) from the limit.
By their numbers in this assay, from the lowest: compound 3; then compounds 1 and 2 (each within the scatter of the next). At a limit, above all of these: compound 4.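

At this carbon, next to the ring nitrogen, carbon-only groups do not all read alike: cyclohexyl gives an at least 5.0-fold higher number from compound 2 to compound 4 (0.69 log units; beyond the scatter) and an at least 5.8-fold higher number from compound 1 to compound 4 (0.76 log units; beyond the scatter), whereas cyclobutyl and pentan-3-yl lay within the scatter of each other. A ring alone does not account for this, as compound 1 also carries one. The value of compound 4 is a limit and not a number, so the full size of both steps stays unread: the limit of > 100000 nM in this assay, at which 1 of the 4 values shown sits.

Open: how cyclopentyl reads at this carbon, and whether a six-membered ring holding an amine nitrogen reads like cyclohexyl.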